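A few compounds are considered here, and "the series" means these few. Any claim that something is new, unique, unknown or untested is made for them only; others in the source may bear on it.

Working notes on the series.

Compound 1 `COc1nc(-c2ccc(Br)cc2)ccc1[C@@H](c1ccccc1)[C@@](O)(CCN(C)C)c1cccc2ccccc12` is the bromo member of the pair measured so far. In a toxicity assay on HeLa cells (Homo sapiens) for cytotoxicity (on this read-out lower numbers stand for higher toxicity in this test and higher numbers for lower toxicity in this test), compound 1 gives only a limit of the assay, > 64 ug/mL. Compound 2 `COc1nc(-c2ccc(F)cc2)ccc1[C@@H](c1ccccc1)[C@@](O)(CCN(C)C)c1cccc2ccccc12` carries fluoro in place of bromo on an aromatic carbon. In this assay compound 2 likewise gives only a limit, > 64 ug/mL. The step from compound 1 to compound 2 is therefore a step that the two limits leave unreadable from compound 1 to compound 2, and nothing can be said of its size or direction. Where compound 2 stands is thus known only as a limit; the evidence on the series reads (the limit of > 64 ug/mL in this assay, at which 2 of the 2 values shown sit).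

Compound 3 `COc1nc(-c2cccc(F)c2)ccc1[C@@H](c1ccccc1)[C@@](O)(CCN(C)C)c1cccc2ccccc12` is the next member to be measured. It differs from compound 2 by 3-fluorophenyl in place of 4-fluorophenyl on an aromatic carbon. For the measured compounds named here, the only measured step, from compound 1 to compound 2, is unreadable and so gives no size to carry over. The expectation is that the step from compound 2 to compound 3 in this assay is a step that the limit leaves unreadable from compound 2 to compound 3, with no movement beyond the scatter to be foreseen. Compound 3 is therefore estimated at 80 ug/mL, between 40 ug/mL and 160 ug/mL, most likely again reported as a limit.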

Compound 3, half-maximal cytotoxic concentration: 62.8 ug/mL
Compound 3: middle estimate off by 1.3-fold (0.11 log units), on the high side; the measured number falls inside the stated range.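

Working notes on the result.

In this assay compound 3 is the only member shown with a readable number, 62.8 ug/mL, rather than a limit, so the aryl group next to the ring nitrogen now has a reference value for later changes at this position. The change to 3-fluorophenyl from 4-fluorophenyl gives an at least 1.0-fold lower number from compound 2 to compound 3 (0.00 log units; that floor lies within the scatter), and the change to 3-fluorophenyl from 4-bromophenyl gives an at least 1.0-fold lower number from compound 1 to compound 3 (0.00 log units; that floor lies within the scatter); neither floor shows a movement beyond the scatter, so shifting the fluorine on this phenyl group cannot yet be said to alter the read-out. The readable number also sits close to the edge of the tested range, and most of the series remains at that edge: the limit of > 64 ug/mL in this assay, at which 2 of the 3 values shown sit.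

Going by these compounds, the true numbers behind the limits of compound 1 and compound 2 remain open, and with them the real size of both steps and of the unreadable exchange of bromo for fluoro. Also open, on these data alone, is whether 3-bromophenyl, or a phenyl group carrying an amine or a carboxylic acid in place of the fluorine, would give a number clearly beyond the scatter from that of compound 3.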